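Two triazole analogues and the limits they share

The compounds below may be only part of what the source reports. "The series", "measured", "known", "first", "only" and "open" are said of these compounds alone.

Among the compounds with values here, the set is built on one shared core, and the three compounds measured so far all stop at the same limit. Compound 1 `Cc1nnc(SCC(=O)c2ccccc2)n1N1C(=O)c2ccccc2C1=O` carries a benzoyl-bearing sulfur chain and a methyl on the core. In a functional assay on MKN-45 cells (Homo sapiens) for cytotoxicity, read by MTT assay, with a stated time of 48 h (on this read-out lower numbers stand for stronger inhibition and higher numbers for weaker inhibition), compound 1 gives > 200000 nM, which is a limit of the assay and not a number. Compound 3 `CCc1nnc(SCC(=O)c2ccccc2)n1N1C(=O)c2ccccc2C1=O` differs from compound 1 by methyl in place of hydrogen on a saturated chain carbon bound to an aromatic carbon. In this assay compound 3 gives > 200000 nM, again a limit. The step that the two limits leave unreadable from compound 1 to compound 3 is therefore unreadable, as is a step that the two limits leave unreadable from compound 2 to compound 3, because the limit of > 200000 nM in this assay, at which 3 of the 3 values shown sit, leaves no gap to measure.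

Compound 2 `C=CCSc1nnc(CC)n1N1C(=O)c2ccccc2C1=O` has the same kind of core, but the difference between the cores of compound 2 and compound 1 is not broken down here. In this assay compound 2 gives > 200000 nM, a limit of the assay. Compound 4 `C=CCSc1nnc(CCC)n1N1C(=O)c2ccccc2C1=O`, not yet measured, differs from compound 2 by methyl in place of hydrogen on a saturated chain carbon, two bonds along the chain from an aromatic carbon. This is the same kind of change as from compound 1 to compound 3, though the place differs: on a saturated chain carbon bound to an aromatic carbon in the one case, two bonds along the chain from an aromatic carbon in the other.

For compound 4 the expected step is a step that the limit leaves unreadable from compound 2 to compound 4, which rests on compound 2 giving only a limit at > 200000 nM. Compound 4 is accordingly estimated at 300000 nM, between 150000 nM and 1000000 nM.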

Compound 4, half-maximal inhibitory concentration: > 200000 nM
Compound 4: a limit, no number (the forecaster's own chance of this, stated with the estimate: 90%); the middle value lies beyond the limit too.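

No new step can be read from compound 2 to compound 4 in this assay because each of the two compounds gives a limit of the assay and not a number: the limit of > 200000 nM in this assay, at which 4 of the 4 values shown sit. The compounds shown leave open whether any change to the sulfur chain, or to the chain on the shared core, would bring a value inside the readable range of this assay at all.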